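The compounds below may be only part of what the source reports. "The series", "measured", "known", "first", "only" and "open" are said of these compounds alone.

Measured in a functional assay on SK-BR-3 cells (Homo sapiens) for cytotoxicity, read by MTT assay, with a stated time of 72 h; a higher number here means a weaker inhibitor, a lower number a stronger inhibitor:
- compound 1 `NCCCNc1c(C(=O)NCc2ccc(F)cc2)nc(Br)c2cccnc12`: "not determined" (no result reported)
- compound 2 `Nc1ccc(Nc2c(C(=O)NCc3ccc(F)cc3)nc(Br)c3cccnc23)cc1`: 4000 nM
- compound 3 `O=C(NCc1ccc(F)cc1)c1nc(Br)c2cccnc2c1N1CCNCC1`: 6000 nM

Among the measured compounds shown here, compound 3, at 6000 nM, has only one measured neighbour and is not separated from it. Compound 1 adds no number. The next compound is compound 4 `COC(=O)CNc1c(C(=O)NCc2ccc(F)cc2)nc(Br)c2cccnc12`, with ((methoxycarbonyl)methyl)amino in place of piperazin-1-yl on an aromatic carbon. For the measured compounds named here, the only measured guide also exchanges the group on an aromatic carbon, and it stayed within the scatter: a 1.5-fold higher number from compound 2 to compound 3 (0.18 log units; within the scatter). A single step is thin evidence, and neither measured group matches the entering ester chain. No shift beyond the scatter is expected in this assay, with an estimated 1.2-fold lower number from compound 3 to compound 4 (0.08 log units; within the scatter). Compound 4 is estimated at 5000 nM, with an expected range of 2000 nM to 12000 nM.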

Compound 4, half-maximal inhibitory concentration: 1000 nM
The estimate for compound 4 lay 5.0-fold (0.70 log units) above the measured number; measured number outside the range, below it.
By their numbers in this assay, from the lowest: compound 4; then compounds 2 and 3 (each within the scatter of the next).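

In this assay the position para to a bromo group now shows a shift beyond the scatter, with a 6.0-fold lower number from compound 3 to compound 4 (0.78 log units; beyond the scatter) and a 4.0-fold lower number from compound 2 to compound 4 (0.60 log units; beyond the scatter). Among the compounds with numbers, the open-chain ((methoxycarbonyl)methyl)amino group therefore stands apart from both piperazin-1-yl and (4-aminophenyl)amino, which remain within the scatter of each other. Nothing available explains this difference. Open, from the compounds shown here alone, is whether the shift belongs to the methyl ester or to the chain as a whole. The corresponding carboxylic acid, a primary amide or a longer chain carrying the same ester would separate these readings.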